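Acyl chain shortening on the compound 1 core

This account rests on a few compounds, and the source may have more. Where it says the series, first, only, none or still open, it means among the compounds named here.

Measured compounds:
compound 1 `CCCCCCCCC(=O)N1c2ccccc2CCC1C(=O)Nc1ccccc1C(F)(F)F` gives 3350 nM
compound 2 `COc1ccc(NC(=O)C2CCc3ccccc3N2)cc1` gives 51400 nM
compound 3 `CCCCCCCCC(=O)N1c2ccccc2CCC1C(=O)Nc1ccccc1O` gives 54300 nM

In a functional assay on MDA-MB-231 cells (Homo sapiens) for cytotoxicity, read by sulforhodamine B assay, with a stated time of 72 h (on this read-out higher numbers stand for weaker inhibition of growth and lower numbers for stronger inhibition of growth), compound 1 stands lowest of the three numbers shown. The nearest is compound 2, and the furthest is compound 3, both beyond the scatter. Among the measured compounds shown here, the one single-point step that is known, a 16-fold higher number from compound 1 to compound 3 (1.21 log units; beyond the scatter), concerns the aryl substituent and not the acyl chain. Compound 2 shares neither the acyl group nor the aryl substituent of compound 1, so its value shows only that a different arrangement of the same core gives a much higher number.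

Compound 4 `CCCC(=O)N1c2ccccc2CCC1C(=O)Nc1ccccc1C(F)(F)F` differs from compound 1 by hydrogen in place of pentyl on a saturated chain carbon, three bonds along the chain from a carbonyl carbon. For the measured compounds named here, no measured step bears directly on this change; the chain is shortened while the aryl side is held constant. With nothing in the series to anchor the chain length, the expectation is a moderate move upward, weaker than the aryl step, and compound 4 is estimated at a 3.0-fold higher number from compound 1 to compound 4 (0.47 log units; beyond the scatter), giving an expected value of 10000 nM with a range from 3000 nM to 40000 nM.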

Compound 4, concentration for 50% growth inhibition: > 70000 nM
Compound 4: a limit, no number (the forecaster's own chance of this, stated with the estimate: 5%); middle value at least 7.0-fold (0.84 log units) away from the limit.
By their numbers in this assay, from the lowest: compound 1; then compounds 2 and 3 (each within the scatter of the next). At a limit, above all of these: compound 4.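

In this assay compound 4 gives > 70000 nM, which is a limit of the assay and not a number. Replacing pentyl with hydrogen at this place on the acyl chain, with the trifluoromethyl side held constant, is an at least 20-fold higher number from compound 1 to compound 4 (1.32 log units; beyond the scatter), so the chain on the shared core also carries a large step, as the aryl side does with a 16-fold higher number from compound 1 to compound 3 (1.21 log units; beyond the scatter). This step is bounded on one side only: the limit of > 70000 nM in this assay, at which 1 of the 4 values shown sits.

Chains between propyl and octyl, and a longer chain such as decyl, remain open, so the series gives no shape for the dependence on chain length. Also open, as far as these compounds go, is how the number moves with an amine or a carboxylic acid at the end of the octyl chain.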